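A few compounds are considered here, and "the series" means these few. Any claim that something is new, unique, unknown or untested is made for them only; others in the source may bear on it.

Series notes. Compound 1 `CC(C)C[C@@H]1NC(=O)[C@H](CS)NC1=O` and compound 2 `CC(C)C[C@@H]1NC(=O)[C@H](Cc2cnc[nH]2)NC1=O` share one core and differ only in the side group. In a functional assay, tested at 2.5 mM (a higher number here means more inhibition at the concentration tested (going by the name of the read-out), a lower number less inhibition), compound 1 gives 88.9%, and compound 2 gives 83.9%. Among the compounds with values here, the one measured step, a number 5 percentage points lower from compound 1 to compound 2 (within the scatter), is within the scatter, so the two numbers cannot be ordered; compound 2 stands level with compound 1 on what has been measured.

Compound 3 `CC(C)C[C@@H]1NC(=O)[C@H](CC(=O)O)NC1=O` is not yet measured. Its change from compound 2: carboxy in place of 1H-imidazol-5-yl on a saturated chain carbon bound to a saturated ring carbon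

Within the data shown here, only the step from compound 1 to compound 2 bears on this change, since it too replaces the side group on the saturated chain carbon bound to a saturated ring carbon, and that step stayed within the scatter. From the compounds shown here alone, a carboxy in place of 1H-imidazol-5-yl is untested here, so the step of a number 1.9 percentage points lower from compound 2 to compound 3 (within the scatter) is expected to be small, no larger than the scatter, in either direction. Compound 3 is estimated at 82%, with a range from 65% to 95%.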

Compound 3, a percentage reported as inhibition, at one concentration (the size of the read-out at that concentration, not a potency): 95%
Compound 3: the middle estimate sits 13 percentage points below what was measured; low and high end bracket the measured number.
By their numbers in this assay, from the lowest: compounds 2, 1 and 3 (each within the scatter of the next, the first and the last beyond it).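

In this assay, within the data shown here, the side group on the saturated chain carbon bound to a saturated ring carbon now shows a first change beyond the scatter: carboxy in place of 1H-imidazol-5-yl gives a number 11.1 percentage points higher from compound 2 to compound 3 (beyond the scatter). Carboxy in place of sulfanyl gives a number 6.1 percentage points higher from compound 1 to compound 3 (within the scatter), so compound 1 and compound 3 cannot be ordered, and the side groups separate only at the two ends of the series. Nothing available explains the step from 1H-imidazol-5-yl to carboxy.

From the compounds shown here alone, whether an amine, or a longer chain ending in a carboxylic acid, would hold the read-out at this position remains open. Each compound is read at a single concentration, so the numbers give no potency, and whether compound 2 and compound 3 keep their order at lower concentrations is also unknown.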